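This account rests on a few compounds, and the source may have more. Where it says the series, first, only, none or still open, it means among the compounds named here.

Measured so far:
compound 1, `CCN(CC)c1ccc(/C=C/C(=O)c2ccc(OC)c3c2OC(C)(C)C=C3)cc1`, in a functional assay on K562 cells (Homo sapiens) for antiproliferative activity, read by MTT assay, with a stated time of 24 h; a lower number here means a stronger inhibitor, a higher number a weaker inhibitor: 790 nM
compound 2, `COc1ccc(C(=O)/C=C/c2ccc(N(c3ccccc3)c3ccccc3)cc2)c2c1C=CC(C)(C)O2`: > 10000 nM
compound 3, `COc1ccc(C(=O)/C=C/c2ccc3ccccc3n2)c2c1C=CC(C)(C)O2`: 3020 nM

Compound 1 gives 790 nM and so stands lowest of the two numbers in hand. Compound 3 gives 3020 nM, a gap beyond the usual scatter. For compound 2 only a limit is reported, not a number: the limit of > 10000 nM in this assay, at which 1 of the 3 values shown sits. No two of the measured compounds differ in a single place, so there is no measured single-group change to lean on.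

Compound 4 is `COc1ccc(C(=O)/C=C/c2ccc(Cl)cc2)c2c1C=CC(C)(C)O2`. It differs from compound 1 in one place: chloro in place of diethylamino on an aromatic carbon. Among the compounds with values here, the compounds measured so far all carry a different group or ring at this end of the molecule, and none of them matches compound 1; compounds 2 and 3 both read weaker or only as a limit. I therefore expect a step of moderate size toward a weaker inhibitor, a 3.2-fold higher number from compound 1 to compound 4 (0.50 log units; beyond the scatter), with considerable uncertainty. Compound 4 is estimated at 2500 nM, expected to fall between 800 nM and 8000 nM.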

Compound 4, half-maximal inhibitory concentration: > 10000 nM
Compound 4 ended at the assay's limit; the forecaster's own chance of this, stated with the estimate: 15%; at least 4.0-fold (0.60 log units) between middle value and limit.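

Within the data shown here, this pair is the only one here that differs in a single place, so it gives the first direct reading of this position: in this assay, chloro in place of diethylamino gives an at least 12-fold higher number from compound 1 to compound 4 (1.10 log units; beyond the scatter). With the rest of the molecule unchanged, the group on this aromatic carbon alone separates a compound with a measurable value from one without, so the shared core does not carry the activity by itself. The full size of the step stays unknown because compound 4 reads only as a limit: the limit of > 10000 nM in this assay, at which 2 of the 4 values shown sit.

With a single replacement to compare, the data cannot separate the part played by the nitrogen of diethylamino from that of its two ethyl chains. As far as these compounds go, a plain amino group, dimethylamino or a pyrrolidine ring at this position would help to tell these apart, and whether any of them keeps the activity of compound 1 remains open.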